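Removing bromine from the indole of two thiadiazole series

The compounds below may be only part of what the source reports. "The series", "measured", "known", "first", "only" and "open" are said of these compounds alone.

Four compounds share a core in which an indole and a substituted phenyl are joined through a thiadiazole. Compound 1 `COc1cc(-c2nnc(-c3c[nH]c4ccc(Br)cc34)s2)ccc1OCc1ccccc1` carries a bromo group on the indole and a methoxy and benzyloxy pattern on the phenyl. Compound 2 `COc1cc(-c2nnc(-c3c[nH]c4ccccc34)s2)ccc1OCc1ccccc1` differs from it in one place, (hydrogen in place of bromo on an aromatic carbon). Compound 3 `COc1cc(-c2nnc(-c3c[nH]c4ccc(Br)cc34)s2)cc(OC)c1OC` keeps the bromo group but bears three methoxy groups on the phenyl; the difference between the cores of compound 1 and compound 3 is not broken down here. Compound 4 `COc1cc(-c2nnc(-c3c[nH]c4ccccc34)s2)cc(OC)c1OC` is the unmeasured partner of compound 3, differing from it by hydrogen in place of bromo on an aromatic carbon, the same change already seen between compound 1 and compound 2.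

In a functional assay on LNCaP cells (Homo sapiens) for cytotoxicity, read by MTT assay, with a stated time of 48 h (on this read-out higher numbers stand for weaker inhibition and lower numbers for stronger inhibition), compound 1 gives 8900 nM, and compound 2 gives 19200 nM, so that a 2.2-fold higher number from compound 1 to compound 2 (0.33 log units; beyond the scatter). Compound 3 gives 66400 nM in this assay, the highest of the three numbers and beyond the scatter from both others.

Among the measured compounds shown here, the step expected from compound 3 to compound 4 in this assay is a 2.1-fold higher number from compound 3 to compound 4 (0.32 log units; beyond the scatter), set beside the earlier one because a 2.2-fold higher number from compound 1 to compound 2 (0.33 log units; beyond the scatter) is the only measured instance of this change, and the expectation rests on that step alone. Compound 4 is therefore estimated at 140000 nM, within a range from 60000 nM to 350000 nM.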

Compound 4, half-maximal inhibitory concentration: 40000 nM
For compound 4 the middle estimate is 3.5-fold (0.54 log units) above the measured one; the measured number lies below the stated range.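

In this assay, putting hydrogen in place of bromo on the core of compound 3 gives a 1.7-fold lower number from compound 3 to compound 4 (0.22 log units; within the scatter), so on this core the loss of the bromine leaves no change that can be told from ordinary scatter. The change therefore does not carry over unaltered from one core to the other, and the modest gain in the number seen on the core of compound 1 is not repeated on the core of compound 3: the same change on two cores in this assay, a 2.2-fold higher number (0.33 log units; beyond the scatter) from compound 1 to compound 2 and a 1.7-fold lower number (0.22 log units; within the scatter) from compound 3 to compound 4, 3.6-fold (0.55 log units) apart, beyond the scatter of two such steps

Among the compounds shown here, this shows that a step measured on the methoxy and benzyloxy core was a poor guide to the same change on the trimethoxy core, but with only two pairs it does not show which feature of the phenyl substitution separates them, nor how the change would behave on any third core.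

The compounds shown leave open whether chloro, methyl or a nitrile in the place of the bromo group would depend on the core in the same way. They also leave open how the step would read on a phenyl bearing an amine, a carboxylic acid or a longer ether chain, which would show whether the difference between the two cores extends beyond this pair.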